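The source may report more compounds than this note shows. Statements on the series, on what has been measured and on what is new or still open speak of the compounds shown alone.

The measured compounds:
compound 1, `O=C1C[C@H](NC(=O)[C@@H]2CNC[C@@H]3CCCC[C@H](NC(=O)c4nccc5ccccc45)C(=O)N32)C(O)O1`, 595 nM
compound 2, `CN1C[C@@H]2CCCC[C@H](NC(=O)c3ccccc3)C(=O)N2[C@H](C(=O)N[C@H]2CC(=O)OC2O)C1`, 247 nM
compound 3, `O=C1C[C@H](NC(=O)[C@@H]2CNC[C@@H]3CCCC[C@H](NC(=O)c4ccccc4)C(=O)N32)C(O)O1`, 384 nM

All three were tested in an assay on isolated protein for inhibition of Caspase-8 (Homo sapiens); on this read-out lower numbers stand for stronger inhibition and higher numbers for weaker inhibition. Compound 3 stands between the other two: a 1.5-fold lower number from compound 1 to compound 3 (0.19 log units; within the scatter) and a 1.6-fold higher number from compound 2 to compound 3 (0.19 log units; within the scatter) are both within the usual scatter, so compound 3 is not set apart from either neighbour by this assay.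

Compound 4 is `O=C1C[C@H](NC(=O)[C@@H]2CN(C(=O)Nc3ccccc3)C[C@@H]3CCCC[C@H](NC(=O)c4ccccc4)C(=O)N32)C(O)O1`. Its change from compound 3 is phenylcarbamoyl in place of hydrogen on an amine nitrogen in a ring. Among the measured compounds shown here, of the two measured steps, only the one from compound 2 to compound 3 touches the same ring nitrogen: there a methyl was exchanged for hydrogen, and the number moved by a 1.6-fold higher number from compound 2 to compound 3 (0.19 log units; within the scatter), within the scatter. For the measured compounds named here, no measured compound carries anything beyond a methyl at that place, so the effect of a phenylcarbamoyl group there is untested. The expected step is therefore a small one, a 1.3-fold lower number from compound 3 to compound 4 (0.11 log units; within the scatter), leaning toward a somewhat lower number. Compound 4 is estimated at 300 nM, expected to fall between 90 nM and 1000 nM.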

Compound 4, half-maximal inhibitory concentration: 601 nM
Compound 4: the middle estimate sits 2.0-fold (0.30 log units) below what was measured; low and high end bracket the measured number.
By their numbers in this assay, from the lowest: compounds 2, 3, 1 and 4 (each within the scatter of the next, the first and the last beyond it).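

Phenylcarbamoyl, with its 9 heavy atoms, is a much larger group on this ring nitrogen than anything in the earlier compounds, yet in this assay the change from hydrogen gives a 1.6-fold higher number from compound 3 to compound 4 (0.19 log units; within the scatter), so this large group is not set apart from hydrogen. Measured against methyl, the same group gives a 2.4-fold higher number from compound 2 to compound 4 (0.39 log units; beyond the scatter), a modest step and the first at this nitrogen to pass beyond the scatter, although each of the two smaller steps linking these compounds through compound 3 stays within it. No measurement shown here accounts for these steps.

Other groups on this nitrogen, such as acetyl, benzyl or a longer alkyl chain, remain open, so no trend with the group's make-up can be drawn yet. Going by these compounds, it is also open whether phenylcarbamoyl would give a similar step with isoquinolin-1-yl in place of phenyl on the carbonyl, as in compound 1.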